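Swapping an amine chain for a carbamoyl group on compound 3

The source may hold more compounds than are shown below. What is called first, only, known or untested is meant among the compounds shown, and "the series" means these compounds.

Of the compounds shown here, three sharing one core have been tested in a functional assay on the whole organism (Tail, strain ICR) with Mus musculus as the target, in the tail flick test, with a stated time of 30 min, at a dose of 25 umol/kg by the oral route; on this read-out higher numbers stand for a stronger effect at the one dose given and lower numbers for a weaker effect. Compound 1 `C[C@H](NC(=O)CN(c1nc(Cl)nc2[nH]cnc12)C1CC1)C(=O)OCc1ccccc1` gives 41.2%. Compound 2 `O=C(CN(c1nc(Cl)nc2[nH]cnc12)C1CC1)NCC(=O)OCc1ccccc1` gives 18.7%. Compound 3 `NCCCC[C@H](NC(=O)CN(c1nc(Cl)nc2[nH]cnc12)C1CC1)C(=O)OCc1ccccc1` gives 26.1%. Among these three numbers compound 3 falls short of compound 1 by a number 15.1 percentage points lower from compound 1 to compound 3 (beyond the scatter), while the pair of compound 2 and compound 3 shows only a number 7.4 percentage points higher from compound 2 to compound 3 (within the scatter), so those two cannot be told apart.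

Compound 4 `NC(=O)CC[C@H](NC(=O)CN(c1nc(Cl)nc2[nH]cnc12)C1CC1)C(=O)OCc1ccccc1` is the next candidate. Its difference from compound 3 is carbamoyl in place of 2-aminoethyl on a saturated chain carbon, three bonds along the chain from an amide-type nitrogen and a carbonyl carbon. The measured steps that touch the same part of the molecule are a number 7.4 percentage points higher from compound 2 to compound 3 (within the scatter) and a number 15.1 percentage points lower from compound 1 to compound 3 (beyond the scatter); both add an amine-bearing chain, and neither introduces a carbamoyl, so they speak only indirectly to the new change. One step stayed within the scatter and the other was modest, which suggests that altering this side chain moves the read-out little. The step from compound 3 to compound 4 is therefore expected to be small, a number 2.1 percentage points lower from compound 3 to compound 4 (within the scatter), in no firm direction. Compound 4 is estimated at 24%, with a range from 10% to 40%.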

Compound 4, a percentage reported as activity, at one dose (the size of the read-out at that dose, not a potency): 30.8%
Compound 4: middle estimate off by 6.8 percentage points, on the low side; low and high end bracket the measured number.
By their numbers in this assay, from the lowest: compounds 2, 3 and 4 (each within the scatter of the next, the first and the last beyond it); then compound 1.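

In this assay, carbamoyl in place of 2-aminoethyl, three bonds along the chain from an amide-type nitrogen and a carbonyl carbon, gives a number 4.7 percentage points higher from compound 3 to compound 4 (within the scatter) and so the two end groups cannot be told apart on this read-out, even though their atoms differ. The 2-carbamoylethyl chain does separate from plain hydrogen on the same carbon, with a number 12.1 percentage points higher from compound 2 to compound 4 (beyond the scatter), whereas the 4-aminobutyl chain gave only a number 7.4 percentage points higher from compound 2 to compound 3 (within the scatter), although this contrast rests on two chains that cannot themselves be told apart. Methyl at this place still holds the lead over the carbamoyl-bearing chain, with a number 10.4 percentage points lower from compound 1 to compound 4 (beyond the scatter), and nothing available here explains why these side chains fall in this order.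

Going by these compounds, it remains open whether a carboxylic acid in place of the carbamoyl would stay level with the carbamoyl-bearing chain or move away from it. On these data alone, it is equally open whether a plain ethyl or a longer chain of carbons alone at this place would match methyl, which would show whether the end group matters at all.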